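3-Methylphenyl in Place of 4-Phenylphenyl: Compound 4

This account rests on a few compounds, and the source may have more. Where it says the series, first, only, none or still open, it means among the compounds named here.

Compound 3 `COC(=O)[C@H](CCSC)NC(=O)c1ccc(NCc2cncn2Cc2ccc(-c3ccccc3)cc2)cc1-c1ccccc1` belongs to a set of three close analogues whose measurements in a functional assay on NIH3T3 cells (Mus musculus) (a higher number here means that more compound is needed for the effect, a lower number that less compound is needed), all end at a limit. In this assay compound 3 gives > 10 uM, which is a limit of the assay and not a number. Compound 1 `COC(=O)[C@H](CCSC)NC(=O)c1ccc(NCc2cncn2Cc2ccc(C#N)cc2)cc1-c1ccccc1` gives > 10 uM in this assay, also a limit. Compound 2 `COC(=O)[C@H](CCSC)NC(=O)c1ccc(NCc2cncn2Cc2cccc(Cl)c2)cc1-c1ccccc1` gives > 10 uM in this assay, once more a limit. The steps among them, a step that the two limits leave unreadable from compound 1 to compound 2, a step that the two limits leave unreadable from compound 1 to compound 3 and a step that the two limits leave unreadable from compound 2 to compound 3, therefore carry no readable size, as the limit of > 10 uM in this assay, at which 3 of the 3 values shown sit, shows. Compound 4 `COC(=O)[C@H](CCSC)NC(=O)c1ccc(NCc2cncn2Cc2cccc(C)c2)cc1-c1ccccc1` differs from compound 3 by 3-methylphenyl in place of 4-phenylphenyl on a saturated chain carbon bound to an aromatic nitrogen. The three unreadable steps, each a change on the same saturated chain carbon bound to an aromatic nitrogen, bear on this change, yet none gives a size or a direction, so no step beyond the scatter can be read from them. Compound 4 is expected to remain near the same limit, the step that the limit leaves unreadable from compound 3 to compound 4 being the estimate. The expected value for compound 4 is 15 uM, ranging from 4 uM to 60 uM.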

Compound 4, concentration for half-maximal effect: > 10 uM
Compound 4 ended at the assay's limit; the forecaster's own chance of this, stated with the estimate: 70%; the middle value lies beyond the limit too.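

Compound 4 also ends at a limit of the assay and not at a number, so no step from it to compound 1, compound 2 or compound 3 can be read: the limit of > 10 uM in this assay, at which 4 of the 4 values shown sit.

The compounds shown leave open whether the groups changed on the saturated chain carbon bound to an aromatic nitrogen differ at all in this assay, and in which direction.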